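Bromo to Chloro Exchange on a Shared Indolinone Fragment

The compounds below may be only part of what the source reports. "The series", "measured", "known", "first", "only" and "open" are said of these compounds alone.

The measured compounds and their values in a functional assay on cells (Melanoma cell, Homo sapiens) for cytotoxicity, read by sulforhodamine B assay, with a stated time of 48 h (on this read-out lower numbers stand for stronger inhibition of growth and higher numbers for weaker inhibition of growth), are:

compound 1, `COc1ccc(C2=NN(C3=NC(=O)/C(=C4\C(=O)Nc5ccc(Br)cc54)S3)C(c3ccc(OC)cc3)C2)cc1`, 190 nM
compound 2, `COc1ccc(C2=NN(C3=NC(=O)/C(=C4\C(=O)Nc5ccc(Cl)cc54)S3)C(c3ccc(OC)cc3)C2)cc1`, 190 nM
compound 3, `CN(C)c1ccc(C2CC(c3ccccc3)=NN2C2=NC(=O)/C(=C3\C(=O)Nc4ccc(Br)cc43)S2)cc1`, 200 nM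

Compound 1 and compound 2 share one core; compound 3 carries a different core, and the difference between the two cores is not broken down here. Compound 1 and compound 2 differ in one place, (chloro in place of bromo on an aromatic carbon), and this gave no change at the digits printed from compound 1 to compound 2 (within the scatter). The values of compound 3 and compound 1, and of compound 3 and compound 2, lie within the usual scatter of each other, so no order among the three can be read from them.

Compound 4, `CN(C)c1ccc(C2CC(c3ccccc3)=NN2C2=NC(=O)/C(=C3\C(=O)Nc4ccc(Cl)cc43)S2)cc1`, has not yet been measured in this assay. It differs from compound 3 by chloro in place of bromo on an aromatic carbon, the same change as that from compound 1 to compound 2, at a place described in identical terms. Because no change at the digits printed from compound 1 to compound 2 (within the scatter) showed no change, the step for compound 4 is expected to be no change at the digits printed from compound 3 to compound 4 (within the scatter), with the value of compound 3 as its starting point. Compound 4 is therefore estimated at 200 nM, expected to lie between 120 nM and 350 nM.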

Compound 4, concentration for 50% growth inhibition: 260 nM
Beside the measured number, compound 4's estimate is 1.3-fold (0.11 log units) below it; the measured number falls inside the stated range.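

In this assay, chloro in place of bromo on the second core gave a 1.3-fold higher number from compound 3 to compound 4 (0.11 log units; within the scatter). Set beside the same exchange on the first core, the two steps agree: the same change on two cores in this assay, no change at the digits printed (within the scatter) from compound 1 to compound 2 and a 1.3-fold higher number (0.11 log units; within the scatter) from compound 3 to compound 4, 1.3-fold (0.11 log units) apart, within the scatter of two such steps Across these two cores, then, the exchange carries over with no step beyond the scatter, but this rests on just two pairs, with the change at a single place, so it does not show that the same would hold on any further core, nor does it rank chloro and bromo against each other.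

The compounds shown carry only bromo or chloro at this place on the aromatic ring, so it remains open how this assay would read with a fluoro, a methoxy or an amine there. Also open is which of the differences between the two cores, such as the dimethylamino group of compound 3 and compound 4, matters on its own, since no pair shown isolates any of them.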